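The source may report more compounds than this note shows. Statements on the series, on what has been measured and on what is new or still open speak of the compounds shown alone.

Measured compounds:
compound 1 `CN1C=CN(C2OC(C(Cl)(Cl)Cl)=CN2c2ccc(S(N)(=O)=O)cc2)C=C1`, 7.55
compound 2 `CC1=CN(c2ccc(S(N)(=O)=O)cc2)C(N2C=CN(C)C=C2)S1`, 7.2
compound 3 `CN1C=CC(C2OC(C(F)(F)F)=CN2c2ccc(S(N)(=O)=O)cc2)C=C1`, 7.33

All three numbers come from a physicochemical assay for acid dissociation. Compound 2 stands at the low end of the three: compound 3 lies within the scatter of compound 2, whereas compound 1 lies beyond the scatter above compound 2. Among the measured compounds shown here, no two measured compounds differ in one place only, so no measured step is available to set a size for the change in question. Compound 4 `CN1C=CN(C2SC(C(F)(F)F)=CN2c2ccc(S(N)(=O)=O)cc2)C=C1` is the compound still to be measured; its difference from compound 2 is trifluoromethyl in place of methyl on a double-bonded ring carbon. Without a comparable measured step, the expectation in this assay is a small step from compound 2 to compound 4, most likely none beyond the scatter, in either direction. The estimate for compound 4 is 7.3, with a range of 6.9 to 7.7. This means an expected step of a number 0.10 log units higher from compound 2 to compound 4 (within the scatter).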

Compound 4, acid dissociation constant: 7.5
For compound 4 the middle estimate is 0.20 log units below the measured one; measured number inside the range.
By their numbers in this assay, from the lowest: compounds 2, 3, 4 and 1 (each within the scatter of the next, the first and the last beyond it).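

In this assay, among the compounds shown here, trifluoromethyl in place of methyl on a double-bonded ring carbon gives a number 0.30 log units higher from compound 2 to compound 4 (within the scatter), the only measured step between compounds differing in one place. At this position, next to the ring sulfur, the exchange therefore stays within the scatter, giving the series its first measured size for a change here. No measured finding bears on the reason for this step.

From the compounds shown here alone, whether an amine or a carboxylic acid at this position would give a step beyond the scatter remains open.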